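From cyano back to methoxy on a new ring

The compounds below may be only part of what the source reports. "The series", "measured", "known", "first", "only" and "open" are said of these compounds alone.

In a functional assay on MCF7 cells (Homo sapiens) for antiproliferative activity, read by MTT assay, with a stated time of 72 h (on this read-out lower numbers stand for stronger inhibition and higher numbers for weaker inhibition), compound 1 `C=CC(=O)Nc1cccc(Oc2nc(Nc3cccc(OC)c3)nc3c2CSCC3)c1` gives > 50000 nM as a limit of the assay, not a number. Among the measured compounds shown here, compound 2 `C=CC(=O)Nc1cccc(Oc2nc(Nc3cccc(C#N)c3)nc3c2CSCC3)c1` gives 21700 nM as the only exact number so far. Compound 3 `C=CC(=O)Nc1cccc(Oc2nc(Nc3ccc(OC)nc3)nc3c2CSCC3)c1` differs from it by 6-methoxypyridin-3-yl in place of 3-cyanophenyl on a nitrogen on an aromatic ring and so loses the cyano group and regains a methoxy group. Cyano in place of methoxy gave an at least 2.3-fold lower number from compound 1 to compound 2 (0.36 log units; beyond the scatter) as the sole measured step, so compound 3 is expected to give back some of that gain, though its methoxy sits on a ring with a hetero atom. The step expected in this assay is a 1.6-fold higher number from compound 2 to compound 3 (0.21 log units; within the scatter) toward weaker inhibition. For compound 3 the estimate is 35000 nM within an expected span from 15000 nM to 50000 nM on this read-out.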

Compound 3, half-maximal inhibitory concentration: 17200 nM
The estimate for compound 3 lay 2.0-fold (0.31 log units) above the measured number; the measured number falls inside the stated range.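

In this assay, a methoxy group on the new ring does not undo the gain from the nitrile: 6-methoxypyridin-3-yl in place of 3-cyanophenyl gives a 1.3-fold lower number from compound 2 to compound 3 (0.10 log units; within the scatter), so the two groups stand level. Against 3-methoxyphenyl, the same group gives an at least 2.9-fold lower number from compound 1 to compound 3 (0.46 log units; beyond the scatter), so a methoxy group as such does not set the read-out at this position. Compound 1 stands at a limit of the assay, so this step has no exact size: the limit of > 50000 nM in this assay, at which 1 of the 3 values shown sits.

Going by these compounds, whether the ring nitrogen or the place of the methoxy group carries that gain stays open. Also open, on these data alone, is how an amine or a carboxylic acid would read on this ring.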